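Aryl swap in a series held at the limit

This account rests on a few compounds, and the source may have more. Where it says the series, first, only, none or still open, it means among the compounds named here.

Measured in a functional assay on KYSE-70 cells for antiproliferative activity against KYSE-70 cell line (Homo sapiens), read by MTT assay, with a stated time of 72 h (on this read-out lower numbers stand for stronger inhibition and higher numbers for weaker inhibition), each value a limit of the assay:
- compound 1 `COc1ccc(NC(=O)c2cc(=O)[nH]c3cc(Br)ccc23)cc1`: > 20000 nM
- compound 2 `O=C(Nc1cccc(F)c1)c1cc(=O)[nH]c2cc(F)ccc12`: > 20000 nM
- compound 3 `CC(=O)c1ccc(-c2ccc3c(C(=O)Nc4cccc(F)c4)cc(=O)[nH]c3c2)cc1`: > 20000 nM

Compound 3 gives no number, only the limit > 20000 nM. The whole set reads as the limit of > 20000 nM in this assay, at which 3 of the 3 values shown sit, so compound 3 cannot be ranked against compound 1 or compound 2.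

The next compound, compound 4 `O=C(Nc1cccc(F)c1)c1cc(=O)[nH]c2cc(-c3ccccc3F)ccc12`, differs from compound 3 in one place: 2-fluorophenyl in place of 4-acetylphenyl on an aromatic carbon. In words, 2-fluorophenyl stands in place of 4-acetylphenyl on an aromatic carbon of the shared core.

Among the measured compounds shown here, one measured step bears on this change: a step that the two limits leave unreadable from compound 2 to compound 3. That step brought in the 4-acetylphenyl that now leaves, and it has no readable size, so neither a size nor a direction can be carried over to this assay. With no measured number anywhere in the set, no step beyond the scatter is expected, and the read-out is expected to remain at the limit. The expected step is a number no higher from compound 3 to compound 4 (the limit leaves the size open). For compound 4 the estimate is 20000 nM, with an expected range from 6000 nM to 40000 nM.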

Compound 4, half-maximal inhibitory concentration: > 20000 nM
Compound 4 gave a limit, no number; the forecaster's own chance of this, stated with the estimate: 65%; the middle value lies on the limit itself.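

In this assay, among the compounds shown here, compound 4 gives > 20000 nM as a limit and not a number, so no step from compound 2 or compound 3 to compound 4 can be read. The compounds shown leave open whether any aryl group on this aromatic carbon of the shared core brings the read-out off the value they all share: the limit of > 20000 nM in this assay, at which 4 of the 4 values shown sit.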